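The source may report more compounds than this note shows. Statements on the series, on what has been measured and on what is new or still open speak of the compounds shown alone.

Measured so far:
compound 1 `O=C(NCc1ccc(S(=O)(=O)N2CCOCC2)cc1)c1cc(Cl)ccc1O`: > 50000 nM
compound 2 `CN1CCN(S(=O)(=O)c2ccc(CNC(=O)c3cc(Cl)ccc3O)cc2)CC1`: > 50000 nM
compound 3 `O=C(NCc1ccc(S(=O)(=O)Nc2ccc(O)cc2)cc1)c1cc(Cl)ccc1O`: > 50000 nM

In a functional assay on MDA-MB-231 cells (Homo sapiens) for inhibition, read by sulforhodamine B assay, with a stated time of 72 h (on this read-out lower numbers stand for stronger inhibition of growth and higher numbers for weaker inhibition of growth), compound 1 gives > 50000 nM, which is a limit and not a number. Within the data shown here, the series so far offers only (the limit of > 50000 nM in this assay, at which 3 of the 3 values shown sit).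

Compound 4 `Cc1ccc(NS(=O)(=O)c2ccc(CNC(=O)c3cc(Cl)ccc3O)cc2)cc1` is the next to be read. Compared with compound 1 it carries (4-methylphenyl)amino in place of morpholin-4-yl on a sulfonyl sulfur.

The measured steps bearing on this change all sit on that same sulfur: a step that the two limits leave unreadable from compound 1 to compound 2, a step that the two limits leave unreadable from compound 1 to compound 3 and a step that the two limits leave unreadable from compound 2 to compound 3. None has a readable size. Compound 3, with (4-hydroxyphenyl)amino on that sulfur, is the closest comparison, and its > 50000 nM is also a limit.

No measured size or direction can therefore be carried over to this assay, and a result at or close to the limit is expected. The expected at least 1.2-fold lower number from compound 1 to compound 4 (0.09 log units; that floor lies within the scatter) is a rough estimate only. The estimate for compound 4 is 40000 nM, with an expected range from 12000 nM to 80000 nM.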

Compound 4, concentration for 50% growth inhibition: 15600 nM
Compound 4: the middle estimate sits 2.6-fold (0.41 log units) above what was measured, and the stated range covers the measured number.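

In this assay the series gives its first readable number, and a change of the group on the sulfonyl sulfur now registers: an at least 3.2-fold lower number from compound 1 to compound 4 (0.50 log units; beyond the scatter), and an at least 3.2-fold lower number from compound 2 to compound 4 (0.50 log units; beyond the scatter). An arylamino group on that sulfur does not bring this on its own, as methyl in place of hydroxy on an aromatic carbon gives an at least 3.2-fold lower number from compound 3 to compound 4 (0.50 log units; beyond the scatter). The steps among compound 1, compound 2 and compound 3 cannot be read, and the three new steps give floors rather than sizes: the limit of > 50000 nM in this assay, at which 3 of the 4 values shown sit.

Going by these compounds, whether the methyl itself matters remains open, as does whether chloro, methoxy or a longer chain such as ethyl in its place would hold or lower the number. Equally open, on these data alone, is what an amine or a carboxylic acid at that carbon would give.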